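The compounds below may be only part of what the source reports. "The series", "measured", "known", "first", "only" and "open" are said of these compounds alone.

- Compound 1 `Cc1n[nH]c2c1C(c1ccc(N(C)C)cc1)C(C(=O)NNC(N)=S)=C(N)N2`: 6260 nM
- Compound 2 `Cc1n[nH]c2c1C(c1ccc(N(C)C)cc1)C(C(=O)NNc1cc([N+](=O)[O-])ccc1[N+](=O)[O-])=C(N)N2`: 8520 nM
- Compound 3 `Cc1n[nH]c2c1C(c1ccc(N(C)C)cc1)C(C(=O)N/N=C/c1ccc(Cl)cc1)=C(N)N2`: not yet measured

In a functional assay on HeLa cells (Homo sapiens) for cytotoxicity, read by MTT assay, with a stated time of 48 h (a higher number here means a weaker inhibitor, a lower number a stronger inhibitor), compound 1 gives 6260 nM. Among the measured compounds shown here, only one other number stands near it, that of compound 2, and the two lie within the usual scatter of each other, so they cannot be ranked.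

Compound 3 differs from compound 1 by a group of 9 heavy atoms (7 carbon, 1 nitrogen, 1 chlorine; one six-membered aromatic ring of carbon only) in place of a group of 4 heavy atoms (1 carbon, 2 nitrogen, 1 sulfur; no ring), on an amide-type nitrogen. For the measured compounds named here, only one measured step bears on this: a 1.4-fold higher number from compound 1 to compound 2 (0.13 log units; within the scatter). That step also brought in a six-membered aromatic ring of carbon only in place of a group with no ring, though on an amine nitrogen and with a different group. One step is thin evidence, so the range stays wide, but no change beyond the scatter is expected in this assay. The expected step is a 1.0-fold higher number from compound 1 to compound 3 (0.02 log units; within the scatter). Compound 3 is estimated at 6500 nM, with a range of 2500 nM to 16000 nM.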

Compound 3, half-maximal inhibitory concentration: 31700 nM
Estimate against measurement, compound 3: 4.9-fold (0.69 log units) below; measured number above the stated range.
By their numbers in this assay, from the lowest: compounds 1 and 2 (each within the scatter of the next); then compound 3.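

In this assay, among the compounds shown here, the group on the amide-type nitrogen can clearly move the number: the change gives a 5.1-fold higher number from compound 1 to compound 3 (0.70 log units; beyond the scatter), the first step in this set to lie beyond the scatter. The earlier step, a 1.4-fold higher number from compound 1 to compound 2 (0.13 log units; within the scatter), also brought in a six-membered aromatic ring of carbon only, yet stayed within the scatter, so the presence of such a ring does not settle the outcome on its own, although that step was on an amine nitrogen and involved a different group. No measurement here accounts for the higher number.

On these data alone, it remains open whether the chlorine or the ring carrying it matters more, which a plain phenyl ring or a methoxy group in place of the chlorine could help separate. A short alkyl chain such as propyl in place of the ring would test whether any aromatic ring is needed for this change at all.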